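From fluoro to chloro on compound 2

This account rests on a few compounds, and the source may have more. Where it says the series, first, only, none or still open, it means among the compounds named here.

Of the compounds shown here, three sharing one core have been measured so far in a functional assay on HeLa cells (Homo sapiens) for antiproliferative activity, read by MTT assay, with a stated time of 48 h (on this read-out higher numbers stand for weaker inhibition and lower numbers for stronger inhibition), and they give close numbers. Compound 1 (`c1ccc(-c2nn(-c3ccccc3)cc2-c2nc3ccccc3[nH]2)cc1`) gives 1550 nM there, compound 2 (`Fc1ccc(-c2nn(-c3ccccc3)cc2-c2nc3ccccc3[nH]2)cc1`) gives 2330 nM there and compound 3 (`Fc1ccc(-c2nn(-c3ccccc3)cc2-c2nc3cc(C(F)(F)F)ccc3[nH]2)cc1`) gives 3520 nM there. The number for compound 2 lies within the usual scatter of each of the other two, so it cannot be clearly separated from either.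

Compound 4 (`Clc1ccc(-c2nn(-c3ccccc3)cc2-c2nc3ccccc3[nH]2)cc1`) has not been measured. Its structure departs from compound 2 at a single place, where the change is chloro in place of fluoro on an aromatic carbon and 4-fluorophenyl becomes 4-chlorophenyl, with chloro in place of fluoro on an aromatic carbon.

Among the measured compounds shown here, no measured compound carries chloro, so only two neighbouring steps offer guidance. With a 1.5-fold higher number from compound 1 to compound 2 (0.18 log units; within the scatter) for fluoro in place of hydrogen and a 1.5-fold higher number from compound 2 to compound 3 (0.18 log units; within the scatter) for trifluoromethyl in place of hydrogen, both within the scatter, no step beyond the scatter is expected in this assay for this swap. The estimated step is a 1.0-fold lower number from compound 2 to compound 4 (0.01 log units; within the scatter) and carries no clear direction. For compound 4 the estimated value is 2300 nM with an expected range from 1100 nM to 4700 nM once it is measured.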

Compound 4, half-maximal inhibitory concentration: 1650 nM
Compound 4: middle estimate off by 1.4-fold (0.14 log units), on the high side, and the stated range covers the measured number.
By their numbers in this assay, from the lowest: compounds 1, 4, 2 and 3 (each within the scatter of the next, the first and the last beyond it).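

In this assay, among the compounds shown here, the halogen itself is exchanged for the first time at this position, para to a large group on the six-membered aromatic ring of carbon only, and chloro in place of fluoro gives a 1.4-fold lower number from compound 2 to compound 4 (0.15 log units; within the scatter). The comparison with the compound carrying only hydrogen at the same place gives a 1.1-fold higher number from compound 1 to compound 4 (0.03 log units; within the scatter), so together with the earlier fluoro step, all three substituents at this carbon remain inside the scatter of one another, and this assay cannot rank hydrogen, fluoro and chloro here. Nothing measured in this set offers an explanation for these numbers.

Hydrogen, fluoro and chloro are single-atom substituents, so it remains open whether a quite different group at this place, such as an amine, a carboxylic acid or a longer chain, would produce a step beyond the scatter. On these data alone, it also remains open whether chloro would give a similarly small step in a compound that also carries the trifluoromethyl group of compound 3 .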